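This account rests on a few compounds, and the source may have more. Where it says the series, first, only, none or still open, it means among the compounds named here.

Measured so far:
compound 1 `COc1cc(C(F)(F)F)cc(C(F)(F)F)c1C(=O)NC1(c2ccccc2)CCCN(S(C)(=O)=O)C1` — > 10000 nM
compound 2 `COc1cc(C(F)(F)F)cc(SC)c1C(=O)NC1(c2ccc(F)cc2)CCCN(C)C1` — 26 nM
compound 3 `COc1cc(C(F)(F)F)cc(SC)c1C(=O)NC1(c2ccc(C)cc2)CCCN(C)C1` — 230 nM

In an assay on cells for inhibition of sodium- and chloride-dependent glycine transporter 1 (Homo sapiens) (a lower number here means that less compound is needed, a higher number that more compound is needed for the effect), compound 3 gives the highest of the two numbers shown, reached by an 8.8-fold higher number from compound 2 to compound 3 (0.95 log units; beyond the scatter). The value of compound 1 is a limit of this assay, not a number (the limit of > 10000 nM in this assay, at which 1 of the 3 values shown sits). Compound 4 `COc1cc(C(F)(F)F)cc(SC)c1C(=O)NC1(c2cccc(Cl)c2)CCCN(C)C1` differs from compound 3 by 3-chlorophenyl in place of 4-methylphenyl on a saturated ring carbon. Within the data shown here, only one measured step touches this aromatic ring, the one from fluoro to methyl, and it raised the number; no measured step covers a chloro substituent. Compound 4 is therefore expected to land somewhat lower than compound 3, an expected step of a 2.3-fold lower number from compound 3 to compound 4 (0.36 log units; beyond the scatter), with wide uncertainty. For compound 4 the estimated value in this assay is 100 nM, within a range of 30 nM to 350 nM.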

Compound 4, half-maximal effective concentration: 25 nM
For compound 4 the middle estimate is 4.0-fold (0.60 log units) above the measured one; the whole stated range lies above it.
By their numbers in this assay, from the lowest: compounds 4 and 2 (each within the scatter of the next); then compound 3. At a limit, above all of these: compound 1.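

In this assay, a change of the aromatic group on this saturated ring carbon can fully reverse the loss seen with 4-methylphenyl: 3-chlorophenyl gives a 9.2-fold lower number from compound 3 to compound 4 (0.96 log units; beyond the scatter) and sits level with 4-fluorophenyl, with a 1.0-fold lower number from compound 2 to compound 4 (0.02 log units; within the scatter) for that pair. The higher number of compound 3 is therefore not shared by all three substituted phenyl groups shown, and 3-chlorophenyl and 4-fluorophenyl cannot be told apart here. Nothing measured here explains either step.

Going by these compounds, it remains open whether 4-chlorophenyl or 3-methylphenyl would separate the effect of the chloro group from that of its ring place. On these data alone, how a nitrile or a methoxy group on this aromatic ring would read is also open.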